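Para-substituent shifts and a difluorophenyl step

The source may report more compounds than this note shows. Statements on the series, on what has been measured and on what is new or still open speak of the compounds shown alone.

Measured compounds:
compound 1, `CC(C)C[C@@H](N)CN(C(=O)[C@@H]1C[C@H]1c1ccccc1)c1ccc(-c2ccccc2)cc1`: 1.8 nM
compound 2, `CC[C@H](C)[C@H](N)CN(C(=O)[C@@H]1C[C@H]1c1ccc(Cl)cc1)c1ccc(-c2ccccc2)cc1`: 4300 nM
compound 3, `CC[C@H](C)[C@H](N)CN(C(=O)[C@@H]1C[C@H]1c1ccccc1F)c1ccc(-c2ccccc2)cc1`: 650 nM

In a functional assay for agonist activity at G protein-coupled receptor 88 (Homo sapiens), read by HTRF and cAMP accumulation (on this read-out higher numbers stand for an effect only at larger amounts of compound and lower numbers for an effect already at smaller amounts), compound 3 gives the second highest of the three numbers. Among the compounds with values here, its nearest neighbour is compound 2; compound 2 gives 4300 nM, and the one step that bears on compound 3 is a 6.6-fold lower number from compound 2 to compound 3 (0.82 log units; beyond the scatter). Compound 1 differs from compound 3 in several places, so only its value and that of compound 3 can be set side by side; in this assay compound 1 gives 1.8 nM.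

Compound 4, `CC[C@H](C)[C@H](N)CN(C(=O)[C@@H]1C[C@H]1c1ccc(F)c(F)c1)c1ccc(-c2ccccc2)cc1`, is not yet measured. It differs from compound 3 in this way: 3,4-difluorophenyl in place of 2-fluorophenyl on a saturated ring carbon. Within the data shown here, the only measured step on that ring carbon, a 6.6-fold lower number from compound 2 to compound 3 (0.82 log units; beyond the scatter), went down when the substituent pattern moved from 4-chlorophenyl to 2-fluorophenyl, and compound 4 brings back a substituent pattern closer to that of compound 2. Compound 4 is therefore expected to give a somewhat higher number in this assay than compound 3, with a modest step of a 2.3-fold higher number from compound 3 to compound 4 (0.36 log units; beyond the scatter). The estimate for compound 4 is 1500 nM, with a range from 400 nM to 6000 nM.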

Compound 4, half-maximal effective concentration: 720 nM
Beside the measured number, compound 4's estimate is 2.1-fold (0.32 log units) above it; the measured number falls inside the stated range.
By their numbers in this assay, from the lowest: compound 1; then compounds 3 and 4 (each within the scatter of the next); then compound 2.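

In this assay, a 1.1-fold higher number from compound 3 to compound 4 (0.04 log units; within the scatter), so on this saturated ring carbon of the three-membered ring, 2-fluorophenyl and 3,4-difluorophenyl cannot be told apart. The other new step, a 6.0-fold lower number from compound 2 to compound 4 (0.78 log units; beyond the scatter), shows that the gap first seen with 2-fluorophenyl also appears with a second fluorinated phenyl group, so among these three compounds both fluorinated groups stand apart from 4-chlorophenyl. No supporting evidence bears on why these numbers fall as they do.

The compounds shown do not separate the effect of the chlorine atom from that of where it sits on the phenyl ring. From the compounds shown here alone, how a methoxy group or a nitrile on that phenyl ring would read in this assay also remains open.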